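Fluoro to Methoxy on the Pendant Aryl of Compound 3

The compounds below may be only part of what the source reports. "The series", "measured", "known", "first", "only" and "open" are said of these compounds alone.

Of the compounds shown here, three have been measured in an ADME assay on microsomes from liver (Homo sapiens) for metabolic stability, tested at 2.5 uM; on this read-out higher numbers stand for fast clearance and lower numbers for slow clearance. Among the compounds with values here, compound 1 `COc1ccc(-c2c(S(=O)(=O)c3cc(F)cc(F)c3)cnc3c(F)cccc23)cc1` gives 2.59 mL/min, and compound 2 `COc1ccc(-c2c(S(=O)(=O)c3ccc(C)c(F)c3)cnc3c(F)cccc23)cc1` gives 3.27 mL/min; the only measured single-point step, a 1.3-fold higher number from compound 1 to compound 2 (0.10 log units; within the scatter), concerns the aryl group on the sulfonyl sulfur and does not bear on the change considered here. Compound 3 `O=S(=O)(c1cc(Cl)cc(Cl)c1)c1cnc2c(F)cccc2c1-c1ccc(F)cc1` gives 1.01 mL/min, the lowest of the three numbers, and its gaps to both compound 1 and compound 2 lie beyond the scatter.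

Compound 4 `COc1ccc(-c2c(S(=O)(=O)c3cc(Cl)cc(Cl)c3)cnc3c(F)cccc23)cc1` differs from compound 3 in one place: methoxy in place of fluoro on an aromatic carbon. Within the data shown here, no measured pair isolates this change. Still, compound 1 and compound 2 both carry the methoxyphenyl that enters here, and both sit well above compound 3 in this assay, though each also differs from compound 3 in the group on the sulfonyl sulfur. Compound 4 is therefore expected to move upward, by a step of a 2.0-fold higher number from compound 3 to compound 4 (0.30 log units; within the scatter), somewhat beyond the scatter. Compound 4 is estimated at 2 mL/min, with a range from 1 mL/min to 4 mL/min.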

Compound 4, intrinsic clearance in a liver preparation (reported as CLH), per the amount of preparation that the assay uses: 2.11 mL/min
Estimate against measurement, compound 4: 1.1-fold (0.02 log units) below, within the range that was stated.
By their numbers in this assay, from the lowest: compound 3; then compounds 4, 1 and 2 (each within the scatter of the next).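

In this assay the exchange of 4-fluorophenyl for 4-methoxyphenyl now stands alone, with 3,5-dichlorophenyl held on the sulfonyl sulfur, and it gives a 2.1-fold higher number from compound 3 to compound 4 (0.32 log units; beyond the scatter) as a step of its own at this position, para to a large group. With the methoxyphenyl held, the group on the sulfonyl sulfur shows no separable effect: the exchanges give a 1.5-fold lower number from compound 2 to compound 4 (0.19 log units; within the scatter) and a 1.2-fold lower number from compound 1 to compound 4 (0.09 log units; within the scatter) and both lie within the scatter. Nothing at hand gives a reason for the step from fluoro to methoxy.

Going by these compounds, whether that step recurs with any other group on the sulfonyl sulfur stays open, as the pair is seen with 3,5-dichlorophenyl only. On these data alone, how an ethoxy, a hydroxyl or an amine on the same aromatic carbon would read also stays open.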